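The source may report more compounds than this note shows. Statements on the series, on what has been measured and on what is new or still open speak of the compounds shown alone.

Of the compounds shown here, three built on one shared core have been tested in a functional assay on HT-29 cells (Homo sapiens) for inhibition, read by MTT assay, with a stated time of 72 h; on this read-out higher numbers stand for weaker inhibition and lower numbers for stronger inhibition. Compound 1 `CNCc1c(OC)cc(Oc2cccc(Nc3ccccc3)c2)cc1OC` gives 7430 nM. Compound 2 `COc1cc(Oc2cccc(Nc3ccccc3)c2)cc(OC)c1CNCc1ccc(C)cc1` gives 3880 nM, and compound 3 `COc1cc(Oc2cccc(Nc3ccccc3)c2)cc(OC)c1CN[C@H](C)c1ccccc1` gives 5120 nM. Of these three numbers, compound 3 holds the second highest, yet the steps of a 1.9-fold lower number from compound 1 to compound 2 (0.28 log units; within the scatter), a 1.5-fold lower number from compound 1 to compound 3 (0.16 log units; within the scatter) and a 1.3-fold higher number from compound 2 to compound 3 (0.12 log units; within the scatter) all lie within the scatter, so none of the three can be told apart on this evidence.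

Compound 4 `COc1ccc(CCCNCc2c(OC)cc(Oc3cccc(Nc4ccccc4)c3)cc2OC)cc1` has not yet been measured. Compared with compound 3 it carries 3-(4-methoxyphenyl)propyl in place of 1-phenylethyl on an amine nitrogen. Going by the values given here, the steps that bear on this change are the three just named, each of which swapped one group for another on the same amine nitrogen and moved the number by no more than the scatter. On that basis the expected step is a 1.1-fold lower number from compound 3 to compound 4 (0.06 log units; within the scatter), nothing beyond the scatter in this assay. Compound 4 is therefore expected to give about 4500 nM, within a range from 1500 nM to 13000 nM.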

Compound 4, half-maximal inhibitory concentration: 3320 nM
Estimate against measurement, compound 4: 1.4-fold (0.13 log units) above; low and high end bracket the measured number.
By their numbers in this assay, from the lowest: compounds 4, 2, 3 and 1 (each within the scatter of the next, the first and the last beyond it).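

On the amine nitrogen, 3-(4-methoxyphenyl)propyl brings 11 heavy atoms in place of the 8 of 1-phenylethyl, along with a hydrogen-bond acceptor and no defined stereocentre, yet in this assay this change gives only a 1.5-fold lower number from compound 3 to compound 4 (0.19 log units; within the scatter). The comparison with the 4-methylbenzyl group is just as small, at a 1.2-fold lower number from compound 2 to compound 4 (0.07 log units; within the scatter), so this position accepts quite different groups with little change in the number. Against the methyl group, however, the result is a 2.2-fold lower number from compound 1 to compound 4 (0.35 log units; beyond the scatter), the only modest step among these four compounds to pass the scatter, and no accompanying measurement explains it.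

The compounds shown leave open whether the methoxy group contributes anything, which a plain 3-phenylpropyl group on the same nitrogen would test. They also leave open how this position responds to a chain ending in a carboxylic acid or to a longer chain with no ring.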